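Compound 3: 2-fluorophenyl in place of pyridin-3-yl

The compounds below may be only part of what the source reports. "The series", "measured", "known", "first", "only" and "open" are said of these compounds alone.

Of the compounds shown here, two have been measured so far in an ADME assay on HepG2 cells (Homo sapiens) for cytotoxicity, in the presence of a further agent that is not named here (a higher number here means a weaker inhibitor, a lower number a stronger inhibitor), and neither gives a number. Compound 1 (`O=C(NCc1ccccc1)c1nc(Cc2ccccc2C(F)(F)F)[nH]c(=O)c1O`) gives > 100000 nM as its result, which is a limit. Compound 2 (`Cn1c(Cc2ccccc2C(F)(F)F)nc(C(=O)NCc2cccnc2)c(O)c1=O`) gives > 100000 nM as its result, which is also a limit. The two therefore share one position, the limit of > 100000 nM in this assay, at which 2 of the 2 values shown sit, and no more can be read from them.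

Compound 3 (`Cn1c(Cc2ccccc2C(F)(F)F)nc(C(=O)NCc2ccccc2F)c(O)c1=O`) follows from compound 2 with 2-fluorophenyl in place of pyridin-3-yl on a saturated chain carbon bound to an amide-type nitrogen. Going by the values given here, no measured step shows what a single change does in this assay, so any expectation is weakly anchored. It rests on compound 2 at > 100000 nM as a limit, and no step beyond the scatter is expected in either direction. The expected step is a number no higher from compound 2 to compound 3 (the limit leaves the size open) and would most likely be hidden by the limit. For compound 3 the estimated value is 100000 nM with an expected range of 40000 nM to 150000 nM in this read-out.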

Compound 3, half-maximal inhibitory concentration: > 100000 nM
Compound 3: only a limit was reported; the forecaster's own chance of this, stated with the estimate: 85%; the middle value sits exactly at the limit.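

No step from compound 2 to compound 3 can be read in this assay, and the series stays at a single position: the limit of > 100000 nM in this assay, at which 3 of the 3 values shown sit.

The compounds shown leave open whether 2-fluorophenyl in place of pyridin-3-yl alters the result at all, and whether any change to the shared core or its side chains would give a number rather than a limit.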